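Trading the End of a Butyl Chain for Hydroxy

A few compounds are considered here, and "the series" means these few. Any claim that something is new, unique, unknown or untested is made for them only; others in the source may bear on it.

In a functional assay on HepG2 cells (Homo sapiens) for cytotoxicity, read by MTT assay, with a stated time of 48 h (a higher number here means a weaker inhibitor, a lower number a stronger inhibitor), compound 1 (`CCOC(=O)/C=C/c1ccc2c(c1)C(=O)C(=O)N2Cc1ccc(OC)cc1`) gives 90 nM. In the same test, compound 2 (`CCCCOC(=O)/C=C/c1ccc2c(c1)C(=O)C(=O)N2Cc1ccc(OC)cc1`) gives 630 nM, the higher of the two actual numbers, which makes it the weaker inhibitor of this pair. Compound 3 (`COC(=O)/C=C/c1cccc2c1N(Cc1ccc(OC)cc1)C(=O)C2=O`) gives only a limit, > 10000 nM, and not a number.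

Compound 4 (`COc1ccc(CN2C(=O)C(=O)c3cc(/C=C/C(=O)OCCO)ccc32)cc1`) has not yet been measured. It differs from compound 2 in one place: hydroxy in place of ethyl on a saturated chain carbon, two bonds along the chain from an oxygen next to a carbonyl group. The same difference reads as butyl to 2-hydroxyethyl (hydroxy in place of ethyl on a saturated chain carbon, two bonds along the chain from an oxygen next to a carbonyl group).

For the measured compounds named here, one measured step bears on this change. Ethyl in place of hydrogen on that same chain carbon gave a 7.0-fold higher number from compound 1 to compound 2 (0.85 log units; beyond the scatter). Compound 4 lacks that ethyl, so part of this rise is expected to reverse, giving a lower number in this assay. Going by the values given here, no measured compound carries the hydroxy group, however, so the size of the step remains uncertain. The expected change is a 2.3-fold lower number from compound 2 to compound 4 (0.35 log units; beyond the scatter). For compound 4, the estimated value is 280 nM, with an expected range from 70 nM to 1500 nM.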

Compound 4, half-maximal inhibitory concentration: 860 nM
Beside the measured number, compound 4's estimate is 3.1-fold (0.49 log units) below it; measured number inside the range.
By their numbers in this assay, from the lowest: compound 1; then compounds 2 and 4 (each within the scatter of the next). At a limit, above all of these: compound 3.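

The end of the chain turns out to matter little here: in this assay, trading ethyl for hydroxy gives a 1.4-fold higher number from compound 2 to compound 4 (0.14 log units; within the scatter), so the butyl and 2-hydroxyethyl versions cannot be told apart in this test. The earlier compounds shown here showed only that adding ethyl to this saturated chain carbon raised the number, and a second group now does the same, since hydroxy in place of hydrogen gives a 9.6-fold higher number from compound 1 to compound 4 (0.98 log units; beyond the scatter) and that step lies well beyond the scatter. Across compounds 1, 2 and 4, then, replacing hydrogen at this carbon counts for more than which of these two groups replaces it, though three compounds make only a narrow basis for that reading.

An amine, a carboxylic acid or a longer chain at the same carbon could either follow compounds 2 and 4 or return towards compound 1, and the compounds shown do not settle which. Nothing among the results given here explains why the number rises at this position or why these two different groups land so close together.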